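From a hydrazide side chain to a methyl amide

The source may report more compounds than this note shows. Statements on the series, on what has been measured and on what is new or still open speak of the compounds shown alone.

- compound 1 `CN1CCN(C(=O)/C=C/c2ccncc2-c2ccc3ccccc3c2)CC1`: > 30000 nM (a limit)
- compound 2 `NNC(=O)COc1ccncc1-c1ccc2ccccc2c1`: "not determined" (no result reported)
- compound 3 `O=C(/C=C/c1ccncc1-c1ccc2ncccc2c1)N1CCOCC1`: "not determined" (no result reported)

These entries come from a functional assay on HCT-116 cells (Homo sapiens) for inhibition, read by MTT assay, with a stated time of 72 h; a lower number here means a stronger inhibitor of growth, a higher number a weaker inhibitor of growth. Compound 1 gives > 30000 nM, which is a limit of the assay and not a number. Compound 2 stands at "not determined" (no result reported), so it has no place on the scale, and no growth-inhibition figure can be read for it. Compound 3 also stands at "not determined" (no result reported). Going by the values given here, the data therefore hold no measured step, and the limit is their only reading.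

Compound 4 `CNC(=O)CCc1ccncc1-c1ccc2ccccc2c1` has yet to be tested. The change is 2-(methylcarbamoyl)ethyl in place of (aminocarbamoyl)methoxy on an aromatic carbon, opposite the ring nitrogen.

With no number for compound 2, the size of this step cannot be anchored at its starting point. Among the compounds with values here, the one available guide is compound 1 at > 30000 nM, a limit, so compound 4 is expected to be a weak inhibitor of growth, with no shift in either direction beyond the scatter from that end of the scale. In this assay, compound 4 is estimated at 20000 nM, with an expected range from 4000 nM to 60000 nM.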

Compound 4, concentration for 50% growth inhibition: 19300 nM
For compound 4 the middle estimate is 1.0-fold (0.02 log units) above the measured one; the measured number falls inside the stated range.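

Going by these compounds alone, compound 2 has no reported result in this assay, so no step to compound 4 can be read. Compound 1 remains a limit of the assay and not a number: the limit of > 30000 nM in this assay, at which 1 of the 4 values shown sits.

The compounds shown leave open how 2-(methylcarbamoyl)ethyl in place of (aminocarbamoyl)methoxy on the shared core changes growth inhibition.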